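This account rests on a few compounds, and the source may have more. Where it says the series, first, only, none or still open, it means among the compounds named here.

Compound 1, with the structure `Cc1cc(-c2nn3c(-c4ccoc4C)nnc3s2)c2ccccc2n1`, was examined in a functional assay on the whole organism (strain Wistar Albino) for inhibition, with Rattus norvegicus as the target, read by paw edema, with a stated time of 4 h, at a dose of 20 mg/kg (a lower number here means less inhibition, a higher number more inhibition at the dose given (going by the name of the read-out)), and gave 26.3%. Compound 2, with the structure `COc1ccc(Cl)c(-c2nnc3sc(-c4ccnc(Cl)c4)nn23)c1`, was examined in the same way and in this assay compound 2 gave 27.2%. On the numbers shown, compound 2 and compound 1 sit within the usual scatter of each other, so neither is set apart from the other. Compound 3, with the structure `COc1ccc(Cl)c(-c2nnc3sc(-c4ccnc(F)c4)nn23)c1`, has not been measured in this assay. It differs from compound 2 in a single place: fluoro in place of chloro on an aromatic carbon. Among the measured compounds shown here, no measured pair shows this exchange, so nothing in the data fixes its size. Given how small the exchange is, the step from compound 2 to compound 3 is expected to be a number 0.2 percentage points lower from compound 2 to compound 3 (within the scatter), that is, none beyond the scatter in either direction. Compound 3 is therefore estimated to give 27% in this assay, with a range from 15% to 40%.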

Compound 3, a percentage reported as inhibition, in the whole organism at one dose (the size of the read-out at that dose, not a potency): 28.1%
Compound 3: the middle estimate sits 1.1 percentage points below what was measured; the range from low to high includes it.
By their numbers in this assay, from the lowest: compounds 1, 2 and 3 (each within the scatter of the next).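

In this assay, fluoro in place of chloro on this aromatic carbon, next to the ring nitrogen, gives a number 0.9 percentage points higher from compound 2 to compound 3 (within the scatter). Among the compounds shown here, this is the first direct reading at this position, and it does not tell the 2-chloropyridin-4-yl and 2-fluoropyridin-4-yl groups apart at the dose given. The result rests on this single pair, and nothing available explains it or bears on how the two halogens act here.

The compounds shown leave open whether an amine or a carboxylic acid at this place would give a number beyond the scatter, and so whether this position matters to the read-out at all. They also leave open whether compound 2 and compound 3 would remain this close at other doses or at other times.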